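Benzimidazole-triazole sulfides: amide aryl swap toward a nitro analogue

The source may report more compounds than this note shows. Statements on the series, on what has been measured and on what is new or still open speak of the compounds shown alone.

Measured so far:
compound 1 `O=[N+]([O-])c1ccc(-n2cc(CSc3nc4cc(OC(F)F)ccc4[nH]3)nn2)cc1` — 203000 nM
compound 2 `O=C(Cn1cc(CSc2nc3cc(OC(F)F)ccc3[nH]2)nn1)Nc1cccc(Cl)c1` — 135000 nM

In a functional assay on B16-F10 cells (Mus musculus) for cytotoxicity, read by MTT assay, with a stated time of 72 h (a lower number here means a stronger inhibitor, a higher number a weaker inhibitor), compound 2 gives 135000 nM, the lower of the two numbers, though compound 1 with 203000 nM sits within the scatter of it, so no order between them is claimed. Compound 3 `Cc1c(NC(=O)Cn2cc(CSc3nc4cc(OC(F)F)ccc4[nH]3)nn2)cccc1[N+](=O)[O-]` differs from compound 2 by 2-methyl-3-nitrophenyl in place of 3-chlorophenyl on an amide-type nitrogen. Among the compounds with values here, no measured pair shows this kind of change, so the step is expected to stay within the scatter in either direction: a 1.1-fold higher number from compound 2 to compound 3 (0.05 log units; within the scatter). Compound 3 is therefore estimated at 150000 nM, with a range from 60000 nM to 350000 nM.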

Compound 3, half-maximal inhibitory concentration: 103000 nM
The estimate for compound 3 lay 1.5-fold (0.16 log units) above the measured number; low and high end bracket the measured number.
By their numbers in this assay, from the lowest: compounds 3, 2 and 1 (each within the scatter of the next).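

Within the data shown here, putting 2-methyl-3-nitrophenyl in place of 3-chlorophenyl on the amide-type nitrogen gives a 1.3-fold lower number from compound 2 to compound 3 (0.12 log units; within the scatter) in this assay and so gives the first reading at this position. The two aryl groups are not separated by this step, even though the entering group carries both a methyl and a nitro group. No evidence on hand explains this result. As far as these compounds go, it remains open whether an unsubstituted phenyl, or an aryl group bearing an amine or a carboxylic acid, would move the number beyond the scatter.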